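Selenocyanate carbamates on colon cells: shortening the chain

This account rests on a few compounds, and the source may have more. Where it says the series, first, only, none or still open, it means among the compounds named here.

Measured compounds:
compound 1 `COc1ccc(OC(=O)Nc2ccc([Se]C#N)cc2)cc1` — 13600 nM
compound 2 `CCCOC(=O)Nc1ccc([Se]C#N)cc1` — 28400 nM
compound 3 `CCCCCCOC(=O)Nc1ccc([Se][Se]c2ccc(NC(=O)OCCCCCC)cc2)cc1` — 11000 nM

In a functional assay on HT-29 cells (Homo sapiens) for cytotoxicity, read by MTT assay, with a stated time of 72 h (on this read-out lower numbers stand for stronger inhibition of growth and higher numbers for weaker inhibition of growth), compound 2 gives 28400 nM, the highest of the three numbers recorded. Compound 1 sits nearest, with a lower number in this assay of 13600 nM, a gap that lies beyond the usual scatter. Furthest from compound 2 lies the diselenide with two hexyl carbamate arms, compound 3, at 11000 nM, again beyond the scatter. Within the data shown here, no pair of these three differs in a single place, so none of these gaps can be tied to one change.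

Compound 4 `CCOC(=O)Nc1ccc([Se]C#N)cc1` is not yet measured. It differs from compound 2 by one change: hydrogen in place of methyl on a saturated chain carbon, two bonds along the chain from an oxygen next to a carbonyl group. Read one bond further out, the carbamate ester goes from propyl to ethyl, from propoxy to ethoxy.

Among the measured compounds shown here, for a change this small, with no measured single-place step to lean on, the expectation in this assay is a step that stays within the usual scatter, with no clear direction. Compound 4 is thus expected near compound 2, at an estimated 30000 nM, in the range 12000 nM to 75000 nM, the estimate implying a step of a 1.1-fold higher number from compound 2 to compound 4 (0.02 log units; within the scatter).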

Compound 4, concentration for 50% growth inhibition: 9300 nM
Estimate against measurement, compound 4: 3.2-fold (0.51 log units) above; measured number below the stated range.
By their numbers in this assay, from the lowest: compounds 4, 3 and 1 (each within the scatter of the next); then compound 2.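

Among these compounds, this is the first single-place step, so one gap can now be tied to one change: in this assay, the move from propoxy to ethoxy on the carbamate ester gives a 3.1-fold lower number from compound 2 to compound 4 (0.48 log units; beyond the scatter), a modest step towards stronger inhibition of growth. The saturated chain carbon two bonds along from the oxygen next to the carbonyl group is therefore not a silent place in this pair, since replacing methyl with hydrogen there removes just one heavy atom, with no ring, hydrogen-bond donor, hydrogen-bond acceptor or net charge leaving, and still moves the number. The direction rests on this single pair, and nothing measured here gives a reason for the step.

From the compounds shown here alone, whether the trend continues along the chain stays open: a methyl carbamate on the same selenocyanate core would show if a further shortening keeps lowering the number, and a butyl carbamate would show if the number keeps rising as the chain grows. A branched isopropyl ester, or a terminal hydroxyl on the ethyl chain, would test whether chain length alone matters at this place.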